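The compounds below may be only part of what the source reports. "The series", "measured", "known", "first", "only" and "open" are said of these compounds alone.

Measured compounds:
- compound 1 `O=c1nc2oc(C3CC3)c(C#CC3CC3)c2cn1Cc1cn(Cc2ccccc2)nn1`: 4810 nM
- compound 2 `O=c1nc2oc(C3CC3)c(C#CC3CC3)c2cn1Cc1cn(-c2ccc(Cl)cc2)nn1`: 39000 nM
- compound 3 `O=c1nc2oc(C3CC3)cc2cn1Cc1cn(-c2ccc(Cl)cc2)nn1`: 61000 nM

All three were run in a functional assay on A549 cells (Homo sapiens) for antiproliferative activity, read by MTT assay, with a stated time of 72 h; a lower number here means a stronger inhibitor, a higher number a weaker inhibitor. Compound 1 gives 4810 nM, compound 2 gives 39000 nM and compound 3 gives 61000 nM in this assay.

Two changes are covered. The first, from compound 2 to compound 1, is benzyl in place of 4-chlorophenyl on an aromatic nitrogen; it made an 8.1-fold lower number from compound 2 to compound 1 (0.91 log units; beyond the scatter). The second, from compound 2 to compound 3, is hydrogen in place of 2-cyclopropylethynyl on an aromatic carbon; it made a 1.6-fold higher number from compound 2 to compound 3 (0.19 log units; within the scatter), so the core of compound 3 and the core of compound 2 cannot be told apart on these numbers.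

Not yet measured is compound 4 `O=c1nc2oc(C3CC3)cc2cn1Cc1cn(Cc2ccccc2)nn1`. From compound 3 it differs by benzyl in place of 4-chlorophenyl on an aromatic nitrogen. The place line reads word for word as for the change from compound 2 to compound 1, so this is the same change, now made on the core that lacks the 2-cyclopropylethynyl group. For the measured compounds named here, the one earlier instance, an 8.1-fold lower number from compound 2 to compound 1 (0.91 log units; beyond the scatter), is the only basis; whether the core matters for this step cannot be checked, since only one pair shows it.

Compound 4 is expected to follow the earlier step, with a 7.6-fold lower number from compound 3 to compound 4 (0.88 log units; beyond the scatter) estimated, because compound 3 sits at 61000 nM and the change gave an 8.1-fold lower number from compound 2 to compound 1 (0.91 log units; beyond the scatter) before. The estimate for compound 4 in this assay is 8000 nM, expected between 3000 nM and 25000 nM.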

Compound 4, half-maximal inhibitory concentration: 45000 nM
The estimate for compound 4 lay 5.6-fold (0.75 log units) below the measured number; measured number outside the range, above it.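

In this assay, benzyl in place of 4-chlorophenyl on an aromatic nitrogen does not carry over from one core to the other; on the core lacking the 2-cyclopropylethynyl group, the step is only a 1.4-fold lower number from compound 3 to compound 4 (0.13 log units; within the scatter), and the comparison with the earlier step stands as follows: the same change on two cores in this assay, an 8.1-fold lower number (0.91 log units; beyond the scatter) from compound 2 to compound 1 and a 1.4-fold lower number (0.13 log units; within the scatter) from compound 3 to compound 4, 6.0-fold (0.78 log units) apart, beyond the scatter of two such steps. The same four compounds read the other way give a 9.4-fold higher number from compound 1 to compound 4 (0.97 log units; beyond the scatter) for hydrogen in place of 2-cyclopropylethynyl on an aromatic carbon with benzyl on the aromatic nitrogen, so the two changes do not act independently here: the same change on two cores in this assay, a 1.6-fold higher number (0.19 log units; within the scatter) from compound 2 to compound 3 and a 9.4-fold higher number (0.97 log units; beyond the scatter) from compound 1 to compound 4, 6.0-fold (0.78 log units) apart, beyond the scatter of two such steps. The gain appears only in compound 1, which carries both benzyl and 2-cyclopropylethynyl, but a single set of four compounds gives one pair per core and shows neither the reason for this dependence nor whether it extends to other groups.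

Still open, from the compounds shown here alone, is whether the dependence persists with a chlorine on the benzyl ring or with a longer chain, such as phenethyl, on the aromatic nitrogen. Also open, going by these compounds, is whether an alkyne ending in a hydroxyl or an amine can stand in for 2-cyclopropylethynyl and keep the number of compound 1.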